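Swapping a methyl for a cyclohexyl on the amidine nitrogen

This account rests on a few compounds, and the source may have more. Where it says the series, first, only, none or still open, it means among the compounds named here.

Measured compounds:
compound 1 `Cc1ccc(CC(CC/N=C(/NCCCc2c[nH]cn2)NC2CCCCC2)c2ccccn2)cc1` – 5.4
compound 2 `CN/C(=N\CCC(c1ccc(Br)cc1)c1ccccn1)NCCCc1c[nH]cn1` – 5.71

Both compounds were tested in a functional assay on ileum for antagonist activity at histamine H1 receptor (Cavia porcellus); a higher number here means a more potent compound, by a factor of ten per unit of this negative logarithm, a lower number a less potent compound. Compound 2 gives 5.71, the higher of the two numbers. Compound 1 gives 5.4, which is lower by a margin beyond the usual scatter of repeated measurements; compounds 1 and 2 differ in more than one place, so this gap cannot be tied to a single change.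

Compound 3 `Brc1ccc(C(CC/N=C(/NCCCc2c[nH]cn2)NC2CCCCC2)c2ccccn2)cc1` has not been measured. Compound 3 is obtained from compound 2 by a single change: cyclohexyl in place of methyl on an amine nitrogen. Within the data shown here, no measured pair in this set differs in only this one place, so there is no measured step that shows directly what this change does in this assay.

The expectation is therefore a modest one: in this assay compound 3 is estimated at 5.6, with a plausible range from 5 to 6.2. The step from compound 2 to compound 3 is expected to be a number 0.11 log units lower from compound 2 to compound 3 (within the scatter), a shift that could fall either way and may well stay within the scatter.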

Compound 3, negative logarithm of the antagonist equilibrium constant: 5.42
Compound 3: middle estimate off by 0.18 log units, on the high side, within the range that was stated.
By their numbers in this assay, from the lowest: compounds 1, 3 and 2 (each within the scatter of the next, the first and the last beyond it).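

In this assay, the change on this amine nitrogen now has a measured step: cyclohexyl in place of methyl gives a number 0.29 log units lower from compound 2 to compound 3 (within the scatter), so six heavy atoms and a ring can stand where a single carbon stood without a shift that can be told from the scatter. Compound 3 also connects compound 1 with compound 2, which differ in more than one place: 4-bromophenyl in place of 4-methylbenzyl on the saturated chain carbon gives a number 0.02 log units higher from compound 1 to compound 3 (within the scatter), so the gap between compound 1 and compound 2 now divides into two single changes, each within the scatter on its own. No other measurement is at hand that could explain either step.

Going by these compounds, what an ethyl or isopropyl group, a phenyl ring, or a longer chain ending in an amine would do on this nitrogen remains open, so the limit on what fits at this position is still unknown. On these data alone, it is also open whether the cyclohexyl for methyl step would read the same with the 4-methylbenzyl group of compound 1 in place of 4-bromophenyl.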